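Exchanging methylsulfonyl for an azetidinyloxy group

A few compounds are considered here, and "the series" means these few. Any claim that something is new, unique, unknown or untested is made for them only; others in the source may bear on it.

Compound 3 `Cc1nc(C)n(CC(=O)N2CCN(c3sc(C(F)(F)F)nc3-c3nc4ccc(S(C)(=O)=O)cc4[nH]3)C[C@H]2C)n1` gives 10 nM in a functional assay on CHO-K1 cells for antagonist activity at C-X-C chemokine receptor type 3 (Homo sapiens), read by FLIPR, with a stated time of 10 min, in the presence of a further agent that is not named here; on this read-out lower numbers stand for stronger inhibition and higher numbers for weaker inhibition. Among the three measured compounds its number is the second highest: compound 1 `Cc1nc(C)n(CC(=O)N2CCN(c3sc(C(F)(F)F)nc3-c3nc4ccc(C5CCOCC5)cc4[nH]3)C[C@H]2C)n1` gives 3.3 nM and compound 2 `Cc1nc(C)n(CC(=O)N2CCN(c3sc(C(F)(F)F)nc3-c3nc4ccc(OC5COC5)cc4[nH]3)C[C@H]2C)n1` gives 68 nM, with the steps of a 3.0-fold higher number from compound 1 to compound 3 (0.48 log units; beyond the scatter) and a 6.8-fold lower number from compound 2 to compound 3 (0.83 log units; beyond the scatter) both beyond the scatter. Compound 4 `Cc1nc(C)n(CC(=O)N2CCN(c3sc(C(F)(F)F)nc3-c3nc4ccc(OC5CNC5)cc4[nH]3)C[C@H]2C)n1` differs from compound 3 in one place: (azetidin-3-yl)oxy in place of methylsulfonyl on an aromatic carbon. The step that bears most on this change is a 6.8-fold lower number from compound 2 to compound 3 (0.83 log units; beyond the scatter), since the (azetidin-3-yl)oxy group of compound 4 resembles the (oxetan-3-yl)oxy group of compound 2 far more than it resembles methylsulfonyl. A move back in the opposite direction is therefore expected, a 5.0-fold higher number from compound 3 to compound 4 (0.70 log units; beyond the scatter). Compound 4 is estimated at 50 nM, with a range from 15 nM to 200 nM.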

Compound 4, half-maximal inhibitory concentration: 3.8 nM
Estimate against measurement, compound 4: 13-fold (1.12 log units) above; measured number below the stated range.
By their numbers in this assay, from the lowest: compounds 1 and 4 (each within the scatter of the next); then compound 3; then compound 2.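

Replacing the oxetane ring with an azetidine ring, with the oxygen link to the aromatic carbon kept, gives an 18-fold lower number from compound 2 to compound 4 (1.25 log units; beyond the scatter), so in this assay this position responds strongly to a change of one ring atom. An oxygen-linked four-membered ring is therefore not poor in itself here: the change from methylsulfonyl gives a 2.6-fold lower number from compound 3 to compound 4 (0.42 log units; beyond the scatter). Replacing oxan-4-yl gives a 1.2-fold higher number from compound 1 to compound 4 (0.06 log units; within the scatter), so these two quite different groups cannot be told apart.

Nothing available explains the effect of the ring atom. Going by these compounds, whether the azetidine hydrogen on nitrogen matters remains open, and an N-methylazetidine or a larger pyrrolidine ring on the same oxygen would address this.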